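From 1,3-Thiazol-5-yl to Pyridin-4-yl: an Untested Step

The source may report more compounds than this note shows. Statements on the series, on what has been measured and on what is new or still open speak of the compounds shown alone.

Three compounds have so far been tested in an assay on HEK293 cells for agonist activity at transient receptor potential cation channel subfamily M member 8 (Homo sapiens), read by fluorescence and calcium flux, with a stated time of 15 min; on this read-out lower numbers stand for an effect already at smaller amounts and higher numbers for an effect only at larger amounts of compound:

compound 1, `CCN(Cc1cc[nH]n1)C(=O)COc1ccc(C)cc1`, gives "not active" (no number reported)
compound 2, `Cc1ccc(OCC(=O)N(Cc2cccs2)CC(C)C)cc1`, gives 900 nM
compound 3, `CCN(Cc1cncs1)C(=O)COc1ccc(C)cc1`, gives 1100 nM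

All three share the same core and differ in the group attached to the amide-type nitrogen. Compound 1 yielded no number at all in this assay. Of the two compounds with a number, compound 3 has the higher one, but its gap to compound 2 lies within the usual scatter, so the two cannot be ranked against each other.

Compound 4, `CCN(Cc1ccncc1)C(=O)COc1ccc(C)cc1`, has not yet been measured. It differs from compound 3 in a single place: pyridin-4-yl in place of 1,3-thiazol-5-yl on a saturated chain carbon bound to an amide-type nitrogen. Going by the values given here, no pair of measured compounds differing in one place is available, so nothing directly tells how large a step this change should bring. Both the leaving and the entering group are small aromatic rings carrying a ring nitrogen, and the rest of the molecule is unchanged. The expectation is therefore a step from compound 3 to compound 4 of a 1.4-fold higher number from compound 3 to compound 4 (0.13 log units; within the scatter), not clearly beyond the scatter. Compound 4 is accordingly estimated at 1500 nM, with a range from 500 nM to 6000 nM.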

Compound 4, half-maximal effective concentration: "not active" (no number reported)
Nothing numeric was reported for compound 4; there is nothing to compare the estimate with.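

In this assay compound 3 gives 1100 nM and compound 4 gives "not active" (no number reported) with no number to set against it, so no step can be read between compound 3 and compound 4. No measurement shown here accounts for this result. As far as these compounds go, how large the change from 1,3-thiazol-5-yl to pyridin-4-yl is in numbers stays open.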